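Methoxy moved on the urea aryl ring

This account rests on a few compounds, and the source may have more. Where it says the series, first, only, none or still open, it means among the compounds named here.

Working notes on ureas built on the shared core of compound 1 `O=C(NCC1(c2ccccc2)CCCCC1)Nc1ccccc1`, all run in an assay on microsomes from intestine for inhibition of acyl-CoA:cholesterol acyltransferase (Oryctolagus cuniculus); on this read-out lower numbers stand for stronger inhibition and higher numbers for weaker inhibition. Compound 1 gives 2300 nM. Compound 2 `COc1ccccc1NC(=O)NCC1(c2ccccc2)CCCCC1` gives 270 nM, and compound 3 `O=C(NCC1(c2ccccc2)CCCCC1)Nc1ccccc1C(F)(F)F` gives 200 nM. Among the three numbers compound 2 stands second highest: the nearest is compound 3, where a 1.4-fold lower number from compound 2 to compound 3 (0.13 log units; within the scatter), and the furthest is compound 1, where an 8.5-fold lower number from compound 1 to compound 2 (0.93 log units; beyond the scatter).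

Compound 4 `COc1cccc(NC(=O)NCC2(c3ccccc3)CCCCC2)c1` is not yet measured; against compound 2 the change is 3-methoxyphenyl in place of 2-methoxyphenyl on an amide-type nitrogen. Within the data shown here, the steps that bear on it are those that place a group on this ring: an 8.5-fold lower number from compound 1 to compound 2 (0.93 log units; beyond the scatter) and a 12-fold lower number from compound 1 to compound 3 (1.06 log units; beyond the scatter), both beyond the scatter, whereas a 1.4-fold lower number from compound 2 to compound 3 (0.13 log units; within the scatter). Among the measured compounds shown here, no measured pair moves a substituent from one ring carbon to another, so the data give no direct guide to such a shift; they show only that the unsubstituted ring of compound 1 sits well above both substituted rings. The expectation is therefore a number somewhat higher than that of compound 2 yet below that of compound 1, held loosely. The expected step is a 2.0-fold higher number from compound 2 to compound 4 (0.31 log units; beyond the scatter). For compound 4 the estimate in this assay is 550 nM, within a range from 150 nM to 2000 nM.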

Compound 4, half-maximal inhibitory concentration: 2500 nM
Beside the measured number, compound 4's estimate is 4.5-fold (0.66 log units) below it, and the stated range ends below it.
By their numbers in this assay, from the lowest: compounds 3 and 2 (each within the scatter of the next); then compounds 1 and 4 (each within the scatter of the next).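

Moving the methoxy with no change in atom count or type gives a 9.3-fold higher number from compound 2 to compound 4 (0.97 log units; beyond the scatter) in this assay, so on this urea aryl ring the place of the group decides the outcome, not merely its presence. The 3-methoxyphenyl urea shows a 1.1-fold higher number from compound 1 to compound 4 (0.04 log units; within the scatter), while the 2-methoxyphenyl urea shows an 8.5-fold lower number from compound 1 to compound 2 (0.93 log units; beyond the scatter); compound 4 therefore goes against any reading of compounds 2 and 3 as showing that a substituent on this ring is enough to lower the number. No measurement shown here explains why the two methoxyphenyl groups part so widely.

Among these compounds, still open is whether the trifluoromethyl of compound 3 would behave as the methoxy does if moved to the ring carbon that carries the methoxy in compound 4, since the present step covers only one group and one move. From the compounds shown here alone, it is also open whether a different group at that ring carbon, such as a hydroxyl, an amine or a carboxylic acid, would give a number apart from those of compound 1 and compound 4, or whether this ring carbon stays flat in this assay whatever it carries.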